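Fluoro in Place of Bromo on a Weakly Active Series

This account rests on a few compounds, and the source may have more. Where it says the series, first, only, none or still open, it means among the compounds named here.

Compound 1 `O=S(=O)(c1ccc(Br)cc1)c1nc2ccccc2nc1N1CCCC1` sets the starting point. In a functional assay on A549 cells (Homo sapiens) for cytotoxicity, read by MTT assay, with a stated time of 72 h (on this read-out lower numbers stand for stronger inhibition and higher numbers for weaker inhibition), compound 1 gives only a limit of the assay, > 50000 nM. Compound 2 `O=S(=O)(c1ccc(F)cc1)c1nc2ccccc2nc1N1CCCC1` differs from it by fluoro in place of bromo on an aromatic carbon; in this assay compound 2 gives 31100 nM. The resulting step is an at least 1.6-fold lower number from compound 1 to compound 2 (0.20 log units; that floor lies within the scatter). Compound 3 `O=S(=O)(c1ccc(Br)cc1)c1nc2ccccc2nc1N1CCc2ccccc2C1` carries a different core, described by 1,2,3,4-tetrahydroisoquinolin-2-yl in place of pyrrolidin-1-yl on an aromatic carbon. In this assay compound 3 gives only a limit of the assay, > 50000 nM. The step is therefore a step that the two limits leave unreadable from compound 1 to compound 3. Two of the three values sit at a limit: the limit of > 50000 nM in this assay, at which 2 of the 3 values shown sit.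

Compound 4 `O=S(=O)(c1ccc(F)cc1)c1nc2ccccc2nc1N1CCc2ccccc2C1` is not yet measured. It differs from compound 3 by fluoro in place of bromo on an aromatic carbon, the same change that leads from compound 1 to compound 2, at a place described in the same words. Compound 4 is expected to give about 38000 nM, with a range from 15000 nM to 50000 nM. The expected step of an at least 1.3-fold lower number from compound 3 to compound 4 (0.11 log units; that floor lies within the scatter) rests on the measured step of an at least 1.6-fold lower number from compound 1 to compound 2 (0.20 log units; that floor lies within the scatter) from compound 1, whose floor lies within the scatter. Since compound 3 sits at a limit, compound 4 may well be reported only as a limit again.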

Compound 4, half-maximal inhibitory concentration: 22900 nM
For compound 4 the middle estimate is 1.7-fold (0.22 log units) above the measured one; measured number inside the range.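

In this assay, as far as these compounds go, fluoro in place of bromo gives an at least 2.1-fold lower number from compound 3 to compound 4 (0.33 log units; beyond the scatter), so on the core of compound 3 the change brings a step beyond the scatter, although its true size remains unknown. This shows that the change can be carried to a second core without losing its direction, but not that it has the same size on both cores: the same change on two cores in this assay, an at least 1.6-fold lower number (0.20 log units; that floor lies within the scatter) from compound 1 to compound 2 and an at least 2.1-fold lower number (0.33 log units; beyond the scatter) from compound 3 to compound 4; the limit leaves it open whether they differ

With fluoro in place, 1,2,3,4-tetrahydroisoquinolin-2-yl and pyrrolidin-1-yl cannot be told apart, as a 1.4-fold lower number from compound 2 to compound 4 (0.13 log units; within the scatter) shows, and with bromo in place the comparison has only limits to rest on: the limit of > 50000 nM in this assay, at which 2 of the 4 values shown sit.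

The compounds shown leave open how other groups on the 4-position of the phenyl ring, such as chloro, methoxy or trifluoromethyl, would read in this assay. They also leave open whether the fluoro step would hold with morpholine or an open-chain amine such as diethylamine in place of the pyrrolidin-1-yl.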